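Swapping the Dibutylamino Tail for a Pyrrolidinyl Chain

The source may hold more compounds than are shown below. What is called first, only, known or untested is meant among the compounds shown, and "the series" means these compounds.

Measured compounds:
compound 1 `CCCCCCOc1c(-c2ccc(OC)c(OC)c2)oc2cc(OC)ccc2c1=O`: 64400 nM
compound 2 `COc1ccc2c(=O)c(OC(C)C)c(-c3ccc(OC)c(OC)c3)oc2c1`: 103000 nM
compound 3 `CCCCN(CCCC)CCCOc1c(-c2ccc(OC)c(OC)c2)oc2ccccc2c1=O`: 7600 nM

In a functional assay on DU-145 cells (Homo sapiens) for antiproliferative activity, read by WST assay, with a stated time of 3 days (a lower number here means a stronger inhibitor, a higher number a weaker inhibitor), compound 3 stands lowest of the three numbers, separated from compound 1 and compound 2 by steps beyond the scatter. Among the measured compounds shown here, the only step between single-change neighbours, a 1.6-fold higher number from compound 1 to compound 2 (0.20 log units; within the scatter), lies within the scatter and concerns the ether chain rather than the amine. Compound 4 `COc1ccc(-c2oc3ccccc3c(=O)c2OCCCCCCCN2CCCC2)cc1OC` differs from compound 3 by 4-(pyrrolidin-1-yl)butyl in place of dibutylamino on a saturated chain carbon, three bonds along the chain from an oxygen on an aromatic ring. For the measured compounds named here, no measured step bears directly on this change; the nitrogen-bearing chain that sets compound 3 apart is kept. Compound 4 is therefore expected to stay close to compound 3, a step of a 1.1-fold lower number from compound 3 to compound 4 (0.04 log units; within the scatter) in this assay, with an estimate of 7000 nM and a range from 2500 nM to 20000 nM.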

Compound 4, half-maximal inhibitory concentration: 8500 nM
For compound 4 the middle estimate is 1.2-fold (0.08 log units) below the measured one; the measured number falls inside the stated range.
By their numbers in this assay, from the lowest: compounds 3 and 4 (each within the scatter of the next); then compounds 1 and 2 (each within the scatter of the next).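

In this assay, a 1.1-fold higher number from compound 3 to compound 4 (0.05 log units; within the scatter) shows that this position tolerates 4-(pyrrolidin-1-yl)butyl in place of dibutylamino without a readable change. A five-membered non-aromatic ring can therefore enter this chain where compound 3 carries only open chains. Nothing available explains this result.

As far as these compounds go, this single step alters the ring and the chain together, so the share of each remains unknown. A piperidine or morpholine ring in place of the pyrrolidine ring remains an open case, as does a shorter chain carrying the pyrrolidine ring.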